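Aryl swap on the enone side of compound 2

The compounds below may be only part of what the source reports. "The series", "measured", "known", "first", "only" and "open" are said of these compounds alone.

The three measured analogues share one core and differ only on the ring attached to the amine. In a functional assay on Bel-7402 cells (Homo sapiens) for cytotoxicity, read by MTT assay (on this read-out lower numbers stand for stronger inhibition and higher numbers for weaker inhibition), compound 1 `Cc1nc(Nc2ccccc2)sc1C(=O)/C=C/c1ccc(Cl)cc1` reaches only the limit of > 25000 nM. Compound 2 `Cc1ccc(Nc2nc(C)c(C(=O)/C=C/c3ccc(Cl)cc3)s2)cc1` likewise sits at the limit of > 25000 nM in this assay. Compound 3 `Cc1nc(Nc2ccc(Cl)cc2)sc1C(=O)/C=C/c1ccc(Cl)cc1` also sits at the limit of > 25000 nM. The steps a step that the two limits leave unreadable from compound 1 to compound 2, a step that the two limits leave unreadable from compound 1 to compound 3 and a step that the two limits leave unreadable from compound 2 to compound 3 are all unreadable, since every value sits at the limit of > 25000 nM in this assay, at which 3 of the 3 values shown sit. Compound 2 thus stands at the limit, with no readable number anywhere in the set.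

Compound 4 `COc1cccc(/C=C/C(=O)c2sc(Nc3ccc(C)cc3)nc2C)c1` differs from compound 2 by 3-methoxyphenyl in place of 4-chlorophenyl on a double-bonded chain carbon bound to a double-bonded chain carbon. Among the measured compounds shown here, no measured step touches this part of the molecule; the three unreadable steps all concern the ring on the amine side and give no size. For compound 4 the expected step is a step that the limit leaves unreadable from compound 2 to compound 4, with no measured basis for a readable gain. Compound 4 is expected to give 30000 nM, within 8000 nM to 120000 nM, most likely again reported as a limit.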

Compound 4, half-maximal inhibitory concentration: > 25000 nM
Compound 4: only a limit was reported (the forecaster's own chance of this, stated with the estimate: 75%); the middle value lies beyond the limit too.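

Compound 4 gives only a limit in this assay, > 25000 nM. Among the compounds shown here, compound 2 also stands at a limit, so no step from it to compound 4 can be read. The compounds shown leave open whether 3-methoxyphenyl in place of 4-chlorophenyl changes cytotoxicity at all.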